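This account rests on a few compounds, and the source may have more. Where it says the series, first, only, none or still open, it means among the compounds named here.

Working notes on the series. For the measured compounds named here, compound 2 `CCOc1cccc(S(=O)(=O)Nc2ccc(N3CCN(c4cccc(-c5c(C(=O)NCCCN6CCN(C)CC6)c(C)n(C)c5-c5ccc(Cl)cc5)c4)CC3)cc2)c1` gives 1620 nM in an assay for inhibition of Apoptosis regulator Bcl-2 (Homo sapiens), read by fluorescence polarization, with a stated time of 2 h (a higher number here means a weaker inhibitor, a lower number a stronger inhibitor), the higher of the two numbers so far, though only within the scatter of compound 1 `Cc1c(C(=O)NCCCN2CCN(C)CC2)c(-c2cccc(N3CCN(c4ccc(NS(=O)(=O)c5cccc(S(=O)(=O)C6CC6)c5)cc4)CC3)c2)c(-c2ccc(Cl)cc2)n1C`, which gives 844 nM in this assay. Compound 3 `Cc1c(C(=O)NCCCN2CCN(C)CC2)c(-c2cccc(N3CCN(c4ccc(NS(=O)(=O)c5cccc(S(=O)(=O)C(F)(F)F)c5)cc4)CC3)c2)c(-c2ccc(Cl)cc2)n1C` differs from compound 2 by (trifluoromethyl)sulfonyl in place of ethoxy on an aromatic carbon. Going by the values given here, the one step that bears on this is a 1.9-fold higher number from compound 1 to compound 2 (0.28 log units; within the scatter); the present change brings a sulfonyl back in, so a step of similar size and opposite sign, within the scatter, is expected. For compound 3 the expected value in this assay is 900 nM, range 350 nM to 2300 nM. The expected step is a 1.8-fold lower number from compound 2 to compound 3 (0.26 log units; within the scatter).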

Compound 3, half-maximal inhibitory concentration: 153 nM
Compound 3: middle estimate off by 5.9-fold (0.77 log units), on the high side, and the stated range ends above it.
By their numbers in this assay, from the lowest: compound 3; then compounds 1 and 2 (each within the scatter of the next).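

In this assay the sulfonyl alone does not set the number at this position: with the sulfonyl kept, trifluoromethyl in place of cyclopropyl on the sulfur gives a 5.5-fold lower number from compound 1 to compound 3 (0.74 log units; beyond the scatter) and lies beyond the scatter. Against ethoxy, the (trifluoromethyl)sulfonyl group gives an 11-fold lower number from compound 2 to compound 3 (1.02 log units; beyond the scatter), whereas cyclopropylsulfonyl stayed within the scatter of ethoxy. Nothing at hand accounts for either step.

Still open, as far as these compounds go, is whether a methyl or an amine on the sulfonyl sulfur would follow trifluoromethyl or cyclopropyl. Also open, from the compounds shown here alone, is how a nitrile on this aromatic carbon would compare.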